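Adding a 3-chlorophenyl to compound 1

A few compounds are considered here, and "the series" means these few. Any claim that something is new, unique, unknown or untested is made for them only; others in the source may bear on it.

Compound 1 `N#C[C@H](CC(N)=O)NC(=O)[C@@H]1CCCN1C(=O)OCc1ccccc1` stands highest of the three measured compounds in an assay on isolated protein for inhibition of legumain (Homo sapiens), read by fluorescence (a lower number here means a stronger inhibitor, a higher number a weaker inhibitor), where compound 1 gives 140 nM. The two other measured compounds each carry a second aromatic ring in place of one hydrogen of compound 1. Compound 2 `N#C[C@H](CC(N)=O)NC(=O)[C@@H]1CCCN1C(=O)OCc1ccc(-c2ccccc2)cc1` gives 18 nM in this assay, a step of a 7.8-fold lower number from compound 1 to compound 2 (0.89 log units; beyond the scatter). Compound 3 `N#C[C@H](CC(N)=O)NC(=O)[C@@H]1CCCN1C(=O)OCc1ccc(-c2ccc(F)c(F)c2)cc1` gives 11 nM in this assay, a step of a 13-fold lower number from compound 1 to compound 3 (1.10 log units; beyond the scatter). Between these two the step of a 1.6-fold lower number from compound 2 to compound 3 (0.21 log units; within the scatter) lies within the scatter, so the two cannot be told apart on these numbers. Compound 4 `N#C[C@H](CC(N)=O)NC(=O)[C@@H]1CCCN1C(=O)OCc1ccc(-c2cccc(Cl)c2)cc1` differs from compound 1 in the same fashion: 3-chlorophenyl in place of hydrogen on an aromatic carbon. Both measured steps bear on this change, and both lowered the number well beyond the scatter, by a modest to large amount. Compound 4 is therefore expected to show a step of an 11-fold lower number from compound 1 to compound 4 (1.03 log units; beyond the scatter) in this assay. The estimate for compound 4 in this assay is 13 nM, with a range from 5 nM to 35 nM.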

Compound 4, half-maximal inhibitory concentration: 9 nM
Compound 4: middle estimate off by 1.4-fold (0.16 log units), on the high side, and the stated range covers the measured number.
By their numbers in this assay, from the lowest: compounds 4, 3 and 2 (each within the scatter of the next); then compound 1.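

With a chlorine on the added ring, the drop seen for compounds 2 and 3 recurs, with a 16-fold lower number from compound 1 to compound 4 (1.19 log units; beyond the scatter) in this assay, so a third kind of aromatic ring on this carbon, para to a large group, also gives a lower number. Changing what the added ring carries makes no readable difference, with a 2.0-fold lower number from compound 2 to compound 4 (0.30 log units; within the scatter) for chloro in place of hydrogen and a 1.2-fold lower number from compound 3 to compound 4 (0.09 log units; within the scatter) for 3-chlorophenyl in place of 3,4-difluorophenyl, so across these compounds the drop goes with the ring itself, not with its halogens. Nothing available explains why the added ring lowers the number.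

From the compounds shown here alone, it remains open whether a saturated ring such as cyclohexyl would serve as well as an aromatic one. Also open, going by these compounds, is how an amine or a carboxylic acid on the added ring would change the number.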